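The source may hold more compounds than are shown below. What is called first, only, known or untested is meant among the compounds shown, and "the series" means these compounds.

Working notes on the series.

Compound 1 `CC(O)(CSc1cccc(S(F)(F)(F)(F)F)c1)C(=O)Nc1ccc(C#N)cc1C(F)(F)F` carries a cyano group on the aromatic ring that bears the amide nitrogen. In a functional assay on LNCaP cells (Homo sapiens) for antiproliferative activity, read by propidium iodide staining, with a stated time of 96 h (a higher number here means a weaker inhibitor, a lower number a stronger inhibitor), compound 1 gives 17600 nM. Compound 2 `CC(O)(CSc1cccc(S(F)(F)(F)(F)F)c1)C(=O)Nc1ccc([N+](=O)[O-])cc1C(F)(F)F` differs from compound 1 by one change, nitro in place of cyano on an aromatic carbon and this change made a step of a 1.4-fold lower number from compound 1 to compound 2 (0.14 log units; within the scatter) in this assay. Compound 2 thus gives 12700 nM in this assay, a number that sits within the scatter of the number for compound 1, so no order between the two can be read from it.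

Compound 3 `CC(O)(CS(=O)(=O)c1cccc(S(F)(F)(F)(F)F)c1)C(=O)Nc1ccc(C#N)cc1C(F)(F)F` has a core differing from that of compound 1; the difference between the two cores is not broken down here. In this assay compound 3 gives 12900 nM, within the scatter of both compound 1 and compound 2.

Compound 4 `CC(O)(CS(=O)(=O)c1cccc(S(F)(F)(F)(F)F)c1)C(=O)Nc1ccc([N+](=O)[O-])cc1C(F)(F)F` is the counterpart of compound 3 built on the pattern of compound 2, the change being (nitro in place of cyano on an aromatic carbon). The place of the change is the same word for word as in the change from compound 1 to compound 2, so this is the same change on the core of compound 3. Within the data shown here, the step from compound 3 to compound 4 in this assay is expected to be a 1.3-fold lower number from compound 3 to compound 4 (0.11 log units; within the scatter), resting on the single earlier instance of this change, which gave a 1.4-fold lower number from compound 1 to compound 2 (0.14 log units; within the scatter), a step that did not leave the scatter. Compound 4 is estimated at 10000 nM in this assay, with a likely range from 5000 nM to 22000 nM, since one small prior step gives little ground to expect a larger movement.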

Compound 4, half-maximal inhibitory concentration: 6500 nM
Compound 4: the middle estimate sits 1.5-fold (0.19 log units) above what was measured; measured number inside the range.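

In this assay, nitro in place of cyano on the second core gives a step of a 2.0-fold lower number from compound 3 to compound 4 (0.30 log units; within the scatter), so no order between these two compounds can be read from it, just as none could be read from the earlier pair. Set side by side, the two steps cannot be told apart: the same change on two cores in this assay, a 1.4-fold lower number (0.14 log units; within the scatter) from compound 1 to compound 2 and a 2.0-fold lower number (0.30 log units; within the scatter) from compound 3 to compound 4, 1.4-fold (0.16 log units) apart, within the scatter of two such steps What this supports is limited: across these two cores, the change behaves alike as far as this assay can tell, with neither step leaving the scatter. It does not show that nitro is better than cyano on either core, and two pairs give no ground for expecting the same result on any other core.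

The compounds shown leave open whether any group other than cyano or nitro on that aromatic carbon, such as an amine, a carboxylic acid or a halogen, would give a step beyond the scatter. They also leave open whether a change elsewhere, such as an amine in place of the hydroxyl group or a longer chain in place of the methyl group, would do so, or would alter how the cyano to nitro change carries between cores.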